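The source may hold more compounds than are shown below. What is called first, only, known or untested is meant among the compounds shown, and "the series" means these compounds.

In a functional assay on A549 cells (Homo sapiens) for inhibition, read by MTT assay, with a stated time of 72 h; on this read-out higher numbers stand for weaker inhibition and lower numbers for stronger inhibition:
- compound 1 (`CC(C)c1ccc(Nc2ccc(C(=O)C(Cl)Cl)cc2[N+](=O)[O-])cc1`): 330 nM
- compound 2 (`CC(C)(O)c1ccc(Nc2ccc(C(=O)C(Cl)Cl)cc2[N+](=O)[O-])cc1`): 3100 nM

Compound 2, at 3100 nM, holds the higher of the two numbers in this assay. Compound 3 (`CC(C)(CO)c1ccc(Nc2ccc(C(=O)C(Cl)Cl)cc2[N+](=O)[O-])cc1`) differs from it by hydroxymethyl in place of hydroxy on a saturated chain carbon bound to an aromatic carbon and two saturated chain carbons. For the measured compounds named here, only one measured step bears on this, a 9.4-fold higher number from compound 1 to compound 2 (0.97 log units; beyond the scatter), where hydroxy replaced hydrogen on that same carbon. Going by the values given here, no measured step shows hydroxymethyl itself, so the expectation is loose: a smaller change than that one, towards a lower number. The expected step is a 1.9-fold lower number from compound 2 to compound 3 (0.29 log units; within the scatter). For compound 3 the estimated value is 1600 nM, within an expected range of 550 nM to 4500 nM.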

Compound 3, half-maximal inhibitory concentration: 3200 nM
For compound 3 the middle estimate is 2.0-fold (0.30 log units) below the measured one, and the stated range covers the measured number.
By their numbers in this assay, from the lowest: compound 1; then compounds 2 and 3 (each within the scatter of the next).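

In this assay, hydroxymethyl in place of hydroxy on this carbon gives a 1.0-fold higher number from compound 2 to compound 3 (0.01 log units; within the scatter) and so leaves compound 2 and compound 3 indistinguishable. Hydroxymethyl in place of hydrogen gives a 9.7-fold higher number from compound 1 to compound 3 (0.99 log units; beyond the scatter) and so shows that the weaker inhibition seen with hydroxy also appears with this second oxygen-bearing group at the same carbon. No evidence is available to explain this result. The compounds shown leave open whether an amine, a carboxylic acid or a methoxy group on this carbon would behave like hydroxy and hydroxymethyl. They also leave open whether a longer chain ending in hydroxy would do so.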